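Swapping a Chain for a Methyl: Little Change Expected

The compounds below may be only part of what the source reports. "The series", "measured", "known", "first", "only" and "open" are said of these compounds alone.

Compound 1 `CC(C)(C)Cc1c(/C=C/c2ccc(Cl)cc2)sc(N)c1C(=O)c1ccc(Cl)cc1` and compound 2 `COCCOc1ccc(-c2sc(N)c(C(=O)c3ccc(Cl)cc3)c2CC(C)(C)C)cc1` share one core and were tested in an assay on CHO cells for displacement of a labelled ligand from adenosine receptor A1 (Homo sapiens), read by scintillation counting, tested at 10 uM; a lower number here means less inhibition, a higher number more inhibition at the concentration tested (going by the name of the read-out). In this assay compound 1 gives 1%. In this assay compound 2 gives 1%, level with compound 1 within the scatter. Compound 3 `Cc1ccc(-c2sc(N)c(C(=O)c3ccc(Cl)cc3)c2CC(C)(C)C)cc1` differs from compound 2 in a single place: methyl in place of 2-methoxyethoxy on an aromatic carbon. Since compound 2 stands at 1%, the step of a number 1 percentage points higher from compound 2 to compound 3 (within the scatter) is expected to be none beyond the scatter. Compound 3 is estimated at 2% in this assay, with a range from -8% to 12%.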

Compound 3, a percentage reported as inhibition, at one concentration (the size of the read-out at that concentration, not a potency): 1%
Compound 3: the middle estimate sits 1 percentage points above what was measured; low and high end bracket the measured number.
By their numbers in this assay, from the lowest: compounds 1, 2 and 3 (each within the scatter of the next).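

In this assay, methyl in place of 2-methoxyethoxy gives no change at the digits printed from compound 2 to compound 3 (within the scatter), so losing the chain with its 2 hydrogen-bond acceptors leaves the reading unmoved. Likewise, 4-methylphenyl in place of 2-(4-chlorophenyl)ethenyl gives no change at the digits printed from compound 1 to compound 3 (within the scatter), so very different groups on this aromatic carbon all read alike. Nothing available explains this flat picture. From the compounds shown here alone, with all three compounds reading so low, it remains open whether any group here can raise inhibition at all. An amine or a carboxylic acid in place of the methyl would be one test.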